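The source may hold more compounds than are shown below. What is called first, only, known or untested is meant among the compounds shown, and "the series" means these compounds.

Measured compounds in a functional assay on HT-29 cells (Homo sapiens) for cytotoxicity, read by MTT assay, with a stated time of 72 h; on this read-out higher numbers stand for weaker inhibition and lower numbers for stronger inhibition:
- compound 1 `COc1cc2c(Oc3ccc(NC(=O)c4cn(-c5ccccc5)nn4)cc3F)ccnc2cc1OCCCN1CCCCC1`: 180 nM
- compound 2 `COc1cc2c(Oc3ccc(NC(=O)c4cn(-c5ccc(Br)cc5)nn4)cc3F)ccnc2cc1OCCCN1CCCCC1`: 260 nM
- compound 3 `COc1cc2c(Oc3ccc(NC(=O)c4cn(-c5c(C)cccc5C)nn4)cc3F)ccnc2cc1OCCCN1CCCCC1`: 3690 nM

Compound 3 carries the highest number of the three in this assay, that is the weakest inhibition. The gap to compound 2, a 14-fold higher number from compound 2 to compound 3 (1.15 log units; beyond the scatter), and the gap to compound 1, a 21-fold higher number from compound 1 to compound 3 (1.31 log units; beyond the scatter), both lie beyond the scatter. Compound 1 and compound 2 are close to one another, a 1.4-fold higher number from compound 1 to compound 2 (0.16 log units; within the scatter), so adding bromo on the aromatic carbon changed little.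

Compound 4 `COc1cc2c(Oc3ccc(NC(=O)c4cn(-c5ccc(F)c(F)c5)nn4)cc3F)ccnc2cc1OCCCN1CCCCC1` is not yet measured. The change from compound 3 is 3,4-difluorophenyl in place of 2,6-dimethylphenyl on an aromatic nitrogen. Both measured steps that bear on it run the other way: putting 2,6-dimethylphenyl on the aromatic nitrogen raised the number sharply from phenyl and from 4-bromophenyl alike. Compound 4 instead has a phenyl with two fluorines, structurally nearer to compound 1 and compound 2 than to compound 3. The bromo step between compound 1 and compound 2 suggests substituents of this kind on the phenyl alter little. A large step down in this assay is therefore expected, roughly undoing the rise seen on the way to compound 3.

Compound 4 is estimated at 250 nM, between 100 nM and 700 nM, an expected step of a 15-fold lower number from compound 3 to compound 4 (1.17 log units; beyond the scatter).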

Compound 4, half-maximal inhibitory concentration: 210 nM
Beside the measured number, compound 4's estimate is 1.2-fold (0.08 log units) above it, within the range that was stated.
By their numbers in this assay, from the lowest: compounds 1, 4 and 2 (each within the scatter of the next); then compound 3.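

In this assay, 3,4-difluorophenyl in place of 2,6-dimethylphenyl on the aromatic nitrogen gives an 18-fold lower number from compound 3 to compound 4 (1.24 log units; beyond the scatter), so carrying two substituents on the phenyl does not by itself go with the high number of compound 3. The two fluorines also leave the read-out within the scatter of the earlier aryl groups, with a 1.2-fold higher number from compound 1 to compound 4 (0.07 log units; within the scatter) and a 1.2-fold lower number from compound 2 to compound 4 (0.09 log units; within the scatter), which means that phenyl, 4-bromophenyl and 3,4-difluorophenyl cannot be told apart at this position in this series. No measurement is available that would explain the large step or the absence of a difference among these three groups.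

Going by these compounds alone, compound 3 is the only compound here with methyl groups on the phenyl, so the set cannot separate the effect of the methyl groups themselves from that of where they sit on the ring. As far as these compounds go, how a phenyl bearing an amine or a carboxylic acid, or a longer chain such as benzyl on the same nitrogen, would read in this assay also remains open.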